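Carboxyalkyl ether chain length on the shared core

The source may report more compounds than this note shows. Statements on the series, on what has been measured and on what is new or still open speak of the compounds shown alone.

Working notes on the series. In a functional assay on A549 cells (Homo sapiens) for cytotoxicity, read by MTT assay (a higher number here means a weaker inhibitor, a lower number a stronger inhibitor), compound 1 `CCOC(=O)COc1cc(O)c2c(=O)c(O)c(-c3ccc(OC)cc3)oc2c1CC=C(C)C` gives 41600 nM. Compound 2 `COc1ccc(-c2oc3c(CC=C(C)C)c(OCCCC(=O)O)cc(O)c3c(=O)c2O)cc1` gives in this assay 19100 nM, the lowest of the three numbers shown, although its gap to compound 3 lies within the scatter. Compound 3 `COc1ccc(-c2oc3c(CC=C(C)C)c(OCCCC(=O)O)cc(O)c3c(=O)c2OCCCC(=O)O)cc1` gives in this assay 26000 nM. The two measured steps are a 2.2-fold lower number from compound 1 to compound 2 (0.34 log units; beyond the scatter) and a 1.4-fold higher number from compound 2 to compound 3 (0.13 log units; within the scatter). Compound 2 therefore stands at the low end, set apart from compound 1 beyond the scatter, but not from compound 3.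

Compound 4 `COc1ccc(-c2oc3c(CC=C(C)C)c(OC(C)C(=O)O)cc(O)c3c(=O)c2O)cc1` has not yet been measured in this assay. It differs from compound 2 in one place: 1-carboxyethyl in place of 3-carboxypropyl on an oxygen on an aromatic ring. Both measured steps bear on it loosely. The step from compound 1 to compound 2 also altered the chain on this oxygen and was only modest; the step from compound 2 to compound 3 added a further 3-carboxypropyl elsewhere and stayed within the scatter. Neither step tests a shorter carboxyalkyl chain directly. With the acid retained and the chain shortened, little movement is expected: a 1.3-fold higher number from compound 2 to compound 4 (0.10 log units; within the scatter) is the expected step. Compound 4 is estimated at 24000 nM, with a range from 10000 nM to 55000 nM.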

Compound 4, half-maximal inhibitory concentration: 15300 nM
Compound 4: middle estimate off by 1.6-fold (0.20 log units), on the high side, within the range that was stated.
By their numbers in this assay, from the lowest: compounds 4, 2, 3 and 1 (each within the scatter of the next, the first and the last beyond it).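

For the compounds shown here, on an oxygen on an aromatic ring, 1-carboxyethyl in place of 3-carboxypropyl gives a 1.2-fold lower number from compound 2 to compound 4 (0.10 log units; within the scatter) in this assay; this is the first step that changes the carboxyalkyl chain with the acid kept, and the two chains cannot be told apart at this level of scatter. Set against (ethoxycarbonyl)methyl on the same oxygen, 1-carboxyethyl gives a 2.7-fold lower number from compound 1 to compound 4 (0.43 log units; beyond the scatter), so both carboxyalkyl chains shown stand apart from the ester-bearing chain, and the size of that gap is no larger than modest. No measurement on hand offers an explanation for either step.

The compounds shown leave open whether the carboxylic acid itself matters at this oxygen, since a primary amide, a tetrazole or a plain methyl ether in the same place would separate the acid from the chain that carries it. They also leave open how a carboxymethyl chain, a longer chain such as 5-carboxypentyl, or the individual mirror-image forms of 1-carboxyethyl would read in this assay.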